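The compounds below may be only part of what the source reports. "The series", "measured", "known", "first", "only" and "open" are said of these compounds alone.

Of the compounds shown here, three that share one core have been tested in a functional assay on MGC-803 cells (Homo sapiens) for inhibition, read by MTT assay, with a stated time of 72 h; on this read-out higher numbers stand for weaker inhibition and lower numbers for stronger inhibition. Compound 1 `CC(C)n1ncc2c(C(=O)Nc3cccnc3)cccc21` gives > 40000 nM, which is a limit of the assay rather than a number. Compound 2 `CC(C)n1ncc2c(C(=O)NCc3ccccc3)cccc21` gives > 40000 nM, again a limit. Compound 3 `CC(C)n1ncc2c(C(=O)NCc3cn(-c4ccccc4)nn3)cccc21` gives > 40000 nM, also a limit. The step that the two limits leave unreadable from compound 1 to compound 2 cannot be read because the limit of > 40000 nM in this assay, at which 3 of the 3 values shown sit, takes in every value recorded, so no size or direction can be drawn from it. Compound 3 therefore stands at the limit, and the numbers shown do not separate it from compound 1 or compound 2.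

Compound 4 `CC(C)n1ncc2c(C(=O)NCc3cn(-c4ccc(I)cc4)nn3)cccc21` differs from compound 3 in a single place: iodo in place of hydrogen on an aromatic carbon. Within the data shown here, no measured step speaks to this change, since every value so far sits at the limit and the one recorded step is unreadable. The step that the limit leaves unreadable from compound 3 to compound 4 is therefore expected to stay within the scatter, if it can be read at all. Compound 4 is expected to give 60000 nM, within a range from 15000 nM to 200000 nM, and most probably only another limit.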

Compound 4, half-maximal inhibitory concentration: > 40000 nM
Compound 4 was reported as a limit (the forecaster's own chance of this, stated with the estimate: 75%); the middle value lies beyond the limit too.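

No step can be read from compound 3 to compound 4, which differ by iodo in place of hydrogen: the limit of > 40000 nM in this assay, at which 4 of the 4 values shown sit. The compounds shown leave open whether any change on the shared core can bring a value inside the measurable range, and how large its effect would be.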